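A few compounds are considered here, and "the series" means these few. Any claim that something is new, unique, unknown or untested is made for them only; others in the source may bear on it.

Compound 1, `CCCCOC1=C(C(=O)c2ccccc2)C(c2ccc(Br)cc2)N(CCCn2ccnc2)C1=O`, is the reference point in this set: in a functional assay on A549 cells (Homo sapiens) for antiproliferative activity, read by MTT assay, with a stated time of 72 h (a higher number here means a weaker inhibitor, a lower number a stronger inhibitor), compound 1 gives 18500 nM. Compound 2, `NC1=C(C(=O)c2ccccc2)C(c2ccc(Br)cc2)N(CCCn2ccnc2)C1=O`, carries a primary amine where compound 1 has a butoxy group, and for compound 2 this assay reports only "not active" (no number reported), with no number attached. Compound 2 therefore stands at the inactive end of the numbers shown, without a figure that can be set against that of compound 1. Compound 3, `CCOc1ccc(NC2=C(C(=O)c3ccccc3)C(c3ccc(Br)cc3)N(CCCn3ccnc3)C2=O)cc1`, differs from compound 2 by 4-ethoxyphenyl in place of hydrogen on an amine nitrogen, so that the amino group becomes a (4-ethoxyphenyl)amino group. For the measured compounds named here, no measured pair shows what such a change does here, so the direction of the step in this assay from compound 2 to compound 3 cannot be read from the data; the expectation is that compound 3 stays within the weak range that compound 1 marks with 18500 nM, with a real chance that again no number is obtained. For compound 3 the expected value in this assay is 25000 nM, with a range from 5000 nM to 100000 nM.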

Compound 3, half-maximal inhibitory concentration: 20200 nM
Beside the measured number, compound 3's estimate is 1.2-fold (0.09 log units) above it; low and high end bracket the measured number.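

On the double-bonded ring carbon, this assay gives a number with (4-ethoxyphenyl)amino just as it does with butoxy: a 1.1-fold higher number from compound 1 to compound 3 (0.04 log units; within the scatter), so the two groups cannot be told apart in this assay. Compound 2, with the unsubstituted amino group, is reported only as not active, whereas compound 3, with 4-ethoxyphenyl on that amine nitrogen, gives 20200 nM, which shows that a substituted amine at this position can return a measurable value. Nothing measured here bears on why the compounds behave this way.

As far as these compounds go, it remains open whether a simpler amine, such as phenylamino without the ethoxy group or butylamino, would also give a number. Also open, from the compounds shown here alone, is whether a longer chain than butoxy, or a carboxylic acid on the phenyl ring, would move the value beyond the scatter.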